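A Methyl for Chloro at the Weak End

The source may hold more compounds than are shown below. What is called first, only, known or untested is meant among the compounds shown, and "the series" means these compounds.

Values in a functional assay on OVCAR-3 cells (Homo sapiens) for inhibition, read by sulforhodamine B assay, with a stated time of 48 h; a lower number here means a stronger inhibitor of growth, a higher number a weaker inhibitor of growth:
Compound 1 `N#Cc1c(-c2nnc(O)c3nn(-c4ccc(Cl)cc4)cc23)nn(-c2ccccc2)c1-c1ccccc1`: 33400 nM
Compound 2 `N#Cc1c(-c2nnc(-c3ccccc3)c3nn(-c4ccccc4)cc23)nn(-c2ccccc2)c1-c1ccccc1`: 93800 nM
Compound 3 `N#Cc1c(-c2nnc(-c3ccccc3)c3nn(-c4ccc(Cl)cc4)cc23)nn(-c2ccccc2)c1-c1ccccc1`: > 100000 nM

Among the compounds with values here, compound 3 has no exact number, only a limit, and it is the one compound here recorded as the limit of > 100000 nM in this assay, at which 1 of the 3 values shown sits. Compound 4 `Cc1ccc(-n2cc3c(-c4nn(-c5ccccc5)c(-c5ccccc5)c4C#N)nnc(-c4ccccc4)c3n2)cc1` keeps everything in compound 3 except one group: methyl in place of chloro on an aromatic carbon, so 4-chlorophenyl becomes 4-methylphenyl.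

The most relevant measured step exchanges hydrogen for that same chloro, and it is an at least 1.0-fold higher number from compound 2 to compound 3 (0.02 log units; that floor lies within the scatter). As far as these compounds go, because this is only a floor, its true size remains unknown. The other measured step, phenyl in place of hydroxy on an aromatic carbon, is an at least 2.9-fold higher number from compound 1 to compound 3 (0.47 log units; beyond the scatter), but it changes a different group and says little about this swap. Compound 2, which carries hydrogen, gives 93800 nM and suggests weak growth inhibition. No change beyond the scatter is therefore expected in this assay, and no direction can be favoured. The expected step is an at least 1.1-fold lower number from compound 3 to compound 4 (0.04 log units; that floor lies within the scatter). The estimated value for compound 4 is 90000 nM, with an expected range of 45000 nM to 150000 nM.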

Compound 4, concentration for 50% growth inhibition: > 100000 nM
Compound 4: only a limit was reported (the forecaster's own chance of this, stated with the estimate: 45%); middle value at least 1.1-fold (0.04 log units) from the limit.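

In this assay compound 4 gives > 100000 nM, which is a limit and not a number. The step from 4-chlorophenyl to 4-methylphenyl therefore cannot be read, and all that can be said is that the two compounds end at the same limit: the limit of > 100000 nM in this assay, at which 2 of the 4 values shown sit.

Set against hydrogen at this position, methyl gives an at least 1.0-fold higher number from compound 2 to compound 4 (0.02 log units; that floor lies within the scatter), so neither methyl nor chloro is seen to bring growth inhibition into a measurable range with this shared core.

As far as these compounds go, how far compound 3 and compound 4 truly lie past the limit remains unknown. The compounds shown carry only hydrogen, chloro and methyl at this position, so it remains open whether a different group there, such as an amine or a carboxylic acid, would give a stronger inhibitor of growth.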